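A small change to a side chain

The compounds below may be only part of what the source reports. "The series", "measured", "known", "first", "only" and "open" are said of these compounds alone.

Measured in a functional assay on A549 cells (Homo sapiens) for antiproliferative activity, read by WST assay, with a stated time of 120 h; a higher number here means a weaker inhibitor, a lower number a stronger inhibitor:
- compound 1 `CCC[C@H]1C[C@@H](OC)C/C(C)=C\[C@@H]2C[C@@H](OC(=O)CCCCc3coc(CCCNC(=O)OC)n3)C[C@H](CC(=O)O1)O2`: > 10000 nM
- compound 2 `CCC[C@H]1C[C@@H](OC)C/C(C)=C\[C@@H]2C[C@@H](OC(=O)/C=C\CCc3coc(C=C(C)C)n3)C[C@H](CC(=O)O1)O2`: 3900 nM

Compound 1 gives no number in this assay, only the limit > 10000 nM. That places it at the limit of > 10000 nM in this assay, at which 1 of the 2 values shown sits. For the measured compounds named here, compound 2 gives a true reading of 3900 nM, and it is the only measured compound that does.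

The next compound is compound 3 `CCC[C@H]1C[C@@H](OC)C/C(C)=C\[C@@H]2C[C@@H](OC(=O)CCCCc3coc(/C=C\CNC(=O)OC)n3)C[C@H](CC(=O)O1)O2`. It keeps the core of compound 1 and changes only the chain on the aromatic carbon of the five-membered aromatic ring: 3-((methoxycarbonyl)amino)prop-1-en-1-yl in place of 3-((methoxycarbonyl)amino)propyl. The change is 3-((methoxycarbonyl)amino)prop-1-en-1-yl in place of 3-((methoxycarbonyl)amino)propyl on an aromatic carbon.

Going by the values given here, no measured pair isolates this change, so any forecast is loose. The expected direction is a modest gain in strength, resting on the reading for compound 2 at 3900 nM. Compound 3 may well give no true reading either. The expected move is an at least 2.5-fold lower number from compound 1 to compound 3 (0.39 log units; beyond the scatter). Compound 3 is estimated at 4000 nM, with an expected range of 500 nM to 15000 nM.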

Compound 3, half-maximal inhibitory concentration: 110 nM
For compound 3 the middle estimate is 36-fold (1.56 log units) above the measured one, outside the stated range (below it).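

The step shows that this position, an aromatic carbon of the five-membered aromatic ring with 1 nitrogen and 1 oxygen, matters strongly in this assay: with the core of compound 1 kept, 3-((methoxycarbonyl)amino)prop-1-en-1-yl in place of 3-((methoxycarbonyl)amino)propyl gives an at least 90-fold lower number from compound 1 to compound 3 (1.95 log units; beyond the scatter). The two chains match in heavy atoms, hydrogen-bond donors and hydrogen-bond acceptors, and the entering chain differs only by its additional double bond outside aromatic rings, yet that change alone brings compound 3 to a true reading of 110 nM. From the compounds shown here alone, compound 1 gives only a limit, > 10000 nM, so the step is a minimum and its full size stays unknown: the limit of > 10000 nM in this assay, at which 1 of the 3 values shown sits.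

The compounds shown leave open whether the double bond must keep the geometry it has in compound 3, or whether its opposite geometry or a triple bond in the same chain would serve as well. They also leave open how much of the chain's far end is needed, for instance whether a free amine could stand in place of the methyl carbamate.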